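This account rests on a few compounds, and the source may have more. Where it says the series, first, only, none or still open, it means among the compounds named here.

Going by the values given here, in a functional assay on MHCC97H cells (Homo sapiens) for antiproliferative activity, read by MTT assay, with a stated time of 48 h (on this read-out higher numbers stand for weaker inhibition and lower numbers for stronger inhibition), compound 1 (`COc1ccc2c(/C=C(\C)C(=O)c3cc(OC)c(OC)c([Se]C)c3)cn(C)c2c1`) gives 15 nM and compound 2 (`COc1cc(C(=O)/C(C)=C/c2c[nH]c3ccccc23)cc([Se]C)c1OC`) gives 18 nM as the only other number so far. These two values lie within the scatter of each other, so compound 2 stands level with compound 1. Compound 3 (`COc1cc(C(=O)/C(C)=C/c2cn(C)c3ccccc23)cc([Se]C)c1OC`) departs from compound 2 in one place: methyl in place of hydrogen on an aromatic nitrogen ( methyl in place of hydrogen on an aromatic nitrogen ). Among the compounds with values here, no measured pair shows this change alone. Within the data shown here, compound 1 already carries a methyl on that nitrogen but also differs from compound 3 elsewhere, and compound 1 with its 15 nM offers the only indirect guide. In this assay no change beyond the scatter is therefore expected, in either direction. The estimated step of a 1.2-fold lower number from compound 2 to compound 3 (0.08 log units; within the scatter) is accordingly small. Compound 3 is estimated at 15 nM with an expected range from 6 nM to 38 nM for now.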

Compound 3, half-maximal inhibitory concentration: 26 nM
Estimate against measurement, compound 3: 1.7-fold (0.24 log units) below, within the range that was stated.
By their numbers in this assay, from the lowest: compounds 1, 2 and 3 (each within the scatter of the next).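

The change now has its first direct reading: in this assay, methyl in place of hydrogen on the aromatic nitrogen of the five-membered ring comes to a 1.4-fold higher number from compound 2 to compound 3 (0.16 log units; within the scatter), so this nitrogen carries either hydrogen or methyl without a step beyond the scatter. The second single change, hydrogen in place of methoxy on an aromatic carbon, gives a 1.7-fold higher number from compound 1 to compound 3 (0.24 log units; within the scatter), so with methyl on the nitrogen, that methoxy is also not tied to a step beyond the scatter. Nothing at hand speaks to why these numbers fall as they do.

Both steps cover only small changes, so the compounds shown leave open whether a longer chain, such as propyl, on that nitrogen would stay within the scatter. They also leave open what an amine or a carboxylic acid would do on that aromatic carbon.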